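The source may hold more compounds than are shown below. What is called first, only, known or untested is meant among the compounds shown, and "the series" means these compounds.

Measured compounds:
compound 1 `O=S(=O)(NCCCNCc1ccc(Cl)c(C(F)(F)F)c1)c1cc(C(F)(F)F)cc(C(F)(F)F)c1` — 7800 nM
compound 2 `O=S(=O)(NCCCNCc1ccc(C(F)(F)F)cc1)c1cc(C(F)(F)F)cc(C(F)(F)F)c1` — 1700 nM
compound 3 `O=S(=O)(NCCCNCc1ccccc1)c1cc(C(F)(F)F)cc(C(F)(F)F)c1` — 13000 nM

In a functional assay on BXPC-3 cells (Homo sapiens) for inhibition, read by MTT assay, with a stated time of 72 h (a lower number here means a stronger inhibitor of growth, a higher number a weaker inhibitor of growth), compound 3 holds the highest number of the three: a 1.7-fold higher number from compound 1 to compound 3 (0.22 log units; within the scatter); a 7.6-fold higher number from compound 2 to compound 3 (0.88 log units; beyond the scatter). Compound 4 `O=S(=O)(NCCCNCc1ccc(-c2ccccc2)cc1)c1cc(C(F)(F)F)cc(C(F)(F)F)c1` differs from compound 3 by phenyl in place of hydrogen on an aromatic carbon. Within the data shown here, the only step that bears on this is the one in which a group leaves the same kind of aromatic carbon, a 7.6-fold higher number from compound 2 to compound 3 (0.88 log units; beyond the scatter), a modest step; the gap between compound 1 and compound 3 is within the scatter and adds little. Filling that carbon again, now with phenyl, is therefore expected to give a lower number, of a size near a 3.3-fold lower number from compound 3 to compound 4 (0.51 log units; beyond the scatter). For compound 4 the estimate is 4000 nM, with a range from 1500 nM to 12000 nM.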

Compound 4, concentration for 50% growth inhibition: 1700 nM
The estimate for compound 4 lay 2.4-fold (0.37 log units) above the measured number; low and high end bracket the measured number.
By their numbers in this assay, from the lowest: compounds 2 and 4 (each within the scatter of the next); then compounds 1 and 3 (each within the scatter of the next).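

In this assay, the aromatic carbon para to a large group accepts a whole phenyl ring, which gives a 7.6-fold lower number from compound 3 to compound 4 (0.88 log units; beyond the scatter). Trifluoromethyl and phenyl read alike at this carbon, with no change at the digits printed from compound 2 to compound 4 (within the scatter), so the lower number is not tied to trifluoromethyl alone. No measurement shown explains why these two groups match.

From the compounds shown here alone, whether an amine, a carboxylic acid or a methoxy group at this carbon would also give a lower number remains open. So does the effect of a longer chain between the sulfonamide and the amine.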